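Adding a Butyl Group to Compound 3: an Expected Gain

The compounds below may be only part of what the source reports. "The series", "measured", "known", "first", "only" and "open" are said of these compounds alone.

Compound 1 `Cc1[nH]c(=O)n(C)c1-c1ccccc1` is the parent of the set. In a functional assay on brain (Rattus norvegicus, strain Wistar) for inhibition (on this read-out higher numbers stand for weaker inhibition and lower numbers for stronger inhibition), compound 1 gives only a limit, > 100000 nM, and no number. Compound 2 `CCCCc1ccc(-c2c(C)[nH]c(=O)n2C)cc1` carries butyl in place of hydrogen on an aromatic carbon and in this assay compound 2 gives 10700 nM, so the step of an at least 9.3-fold lower number from compound 1 to compound 2 (0.97 log units; beyond the scatter) is at least modest, its size bounded by the limit of > 100000 nM in this assay, at which 1 of the 3 values shown sits. Compound 3 `Cc1[nH]c(=O)n(C2CCCCC2)c1-c1ccccc1` differs from compound 1 by cyclohexyl in place of methyl on an aromatic nitrogen; in this assay compound 3 gives 47600 nM, a higher number than compound 2.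

Compound 4 `CCCCc1ccc(-c2c(C)[nH]c(=O)n2C2CCCCC2)cc1`, not yet measured, carries the same kind of change relative to compound 3, (butyl in place of hydrogen on an aromatic carbon); here the butyl enters para to a large group, whereas in compound 2 it sits para to a group of 8 heavy atoms. Because the first butyl step gave an at least 9.3-fold lower number from compound 1 to compound 2 (0.97 log units; beyond the scatter), compound 4 is expected to show a step of similar size, an 11-fold lower number from compound 3 to compound 4 (1.02 log units; beyond the scatter). Compound 4 is thus estimated at 4500 nM in this assay, most likely between 1200 nM and 15000 nM.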

Compound 4, half-maximal inhibitory concentration: 27100 nM
Estimate against measurement, compound 4: 6.0-fold (0.78 log units) below; the measured number lies above the stated range.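

In this assay, butyl in place of hydrogen on the core of compound 3 gives a 1.8-fold lower number from compound 3 to compound 4 (0.24 log units; within the scatter), so the step seen on the core of compound 1 does not carry over at its earlier size: the same change on two cores in this assay, an at least 9.3-fold lower number (0.97 log units; beyond the scatter) from compound 1 to compound 2 and a 1.8-fold lower number (0.24 log units; within the scatter) from compound 3 to compound 4, at least 5.3-fold (0.72 log units) apart, beyond the scatter of two such steps

The cyclohexyl change also differs between cores, giving a 2.5-fold higher number from compound 2 to compound 4 (0.40 log units; beyond the scatter) when the butyl is present: the same change on two cores in this assay, an at least 2.1-fold lower number (0.32 log units; beyond the scatter) from compound 1 to compound 3 and a 2.5-fold higher number (0.40 log units; beyond the scatter) from compound 2 to compound 4, at least 5.3-fold (0.72 log units) apart, beyond the scatter of two such steps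

Both earlier steps remain bounds rather than exact sizes, and the numbers do not show why the steps differ: the limit of > 100000 nM in this assay, at which 1 of the 4 values shown sits.

The compounds shown leave open whether a propyl or hexyl chain, an amine or a carboxylic acid in the place of the butyl would follow either step. They also leave open how ethyl or benzyl on the aromatic nitrogen would behave.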